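A few compounds are considered here, and "the series" means these few. Any claim that something is new, unique, unknown or untested is made for them only; others in the source may bear on it.

Compound 1 `COc1ccc(Cn2c(N)nc3cc(Cl)c(Cl)cc32)cc1` gives 27000 nM 
Compound 2 `Cc1cccc(Cn2c(N)nc3cc(Cl)c(Cl)cc32)c1` gives 48000 nM 

Both numbers come from a functional assay on CEM-SS cells (Homo sapiens) for cytotoxicity (on this read-out higher numbers stand for weaker inhibition and lower numbers for stronger inhibition), and they lie within the usual scatter of each other, so compound 1 cannot be ranked against compound 2 on these data. Attention now turns to compound 3 `Nc1nc2cc(Cl)c(Cl)cc2n1Cc1ccc(F)cc1` which has not yet been measured. Set against compound 1, its structure shows this change: fluoro in place of methoxy on an aromatic carbon that is, fluoro in place of methoxy on an aromatic carbon, para to a large group. Within the data shown here, no step between measured compounds is available to size this change, so there is no direct precedent for it. Among the measured compounds shown here, the only guide is the narrow spread of the two measured values, with compound 1 at 27000 nM and compound 2 at 48000 nM within the scatter. As far as these compounds go, on that basis, no step beyond the scatter is expected in this assay and the direction remains open. The expected change is a 1.3-fold higher number from compound 1 to compound 3 (0.11 log units; within the scatter) as an estimate only. Compound 3 is estimated at 35000 nM with an expected range from 15000 nM to 80000 nM in this read-out.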

Compound 3, half-maximal inhibitory concentration: 30000 nM
Estimate against measurement, compound 3: 1.2-fold (0.07 log units) above; low and high end bracket the measured number.
By their numbers in this assay, from the lowest: compounds 1, 3 and 2 (each within the scatter of the next).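

Among these compounds, the step for fluoro in place of methoxy on an aromatic carbon, para to a large group, is the first that sizes a change at this position: in this assay it is a 1.1-fold higher number from compound 1 to compound 3 (0.05 log units; within the scatter). A group of two heavy atoms with one hydrogen-bond acceptor gives way here to a single heavy atom with no hydrogen-bond acceptor, and the two numbers still lie within the scatter of each other. On this evidence, this exchange at this position gives no readable difference in this assay, although a single step says nothing about other groups at the same carbon.

As far as these compounds go, whether an amine, a carboxylic acid or a longer chain on this same aromatic carbon would give a step beyond the scatter remains open. All three compounds also keep the shared core unchanged, so what a change in the core would do in this assay is open too.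

Nothing available accounts for the size of this step.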